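Removing one amidine from a bis-amidine indole

The compounds below may be only part of what the source reports. "The series", "measured", "known", "first", "only" and "open" are said of these compounds alone.

Compound 1 `N=C(N)c1ccc(Cn2ccc3cc(C(=N)N)ccc32)cc1` is the reference point of this small set. In an assay on isolated protein for inhibition of serine protease 1 (Bos taurus) (on this read-out higher numbers stand for weaker inhibition and lower numbers for stronger inhibition), compound 1 gives 3180 nM, the lowest of the three numbers. Compound 2 `N=C(N)c1ccc(Cn2ccc3cc(C(=N)N)ccc32)c(Cl)c1` gives 5310 nM, and the step of a 1.7-fold higher number from compound 1 to compound 2 (0.22 log units; within the scatter) stays within the scatter. Compound 3 `N=C(N)c1ccc2c(ccn2Cc2cccc([N+](=O)[O-])c2)c1` gives 7770 nM; its number lies beyond the scatter above that of compound 1, and since compound 3 differs from compound 1 in more than one place, only the two values themselves can be compared.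

Compound 4 `N=C(N)c1ccc(Cn2ccc3ccccc32)cc1` has not yet been measured. It differs from compound 1 by a hydrogen atom in place of a group of 3 heavy atoms (1 carbon, 2 nitrogen; no ring), on an aromatic carbon, the position being on an aromatic carbon of a six-membered aromatic ring of carbon only, part of a fused system of two rings, meta to a fused ring and para to a fused ring. For the measured compounds named here, none of the measured steps touches this part of the core; the single measured step concerns a chloro group on the other ring and was small. The values of compound 1 and compound 3 show that a compound carrying only one amidine still yields a measurable number in this assay.

For compound 4 the step of a 4.7-fold higher number from compound 1 to compound 4 (0.67 log units; beyond the scatter) is expected to lie beyond the scatter toward weaker inhibition. Compound 4 is therefore estimated at 15000 nM, with a likely range from 5000 nM to 50000 nM.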

Compound 4, inhibition constant: 4590 nM
Beside the measured number, compound 4's estimate is 3.3-fold (0.51 log units) above it; the whole stated range lies above it.
By their numbers in this assay, from the lowest: compounds 1, 4, 2 and 3 (each within the scatter of the next, the first and the last beyond it).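

In this assay, the step of a 1.4-fold higher number from compound 1 to compound 4 (0.16 log units; within the scatter) shows that, on this aromatic carbon of the six-membered aromatic ring of carbon only, a hydrogen atom can stand in place of the group of 3 heavy atoms (1 carbon, 2 nitrogen; no ring) without a difference that can be told from the scatter. For the compounds shown here, the earlier compounds held no step at this position, as their single step in one place concerned a chloro group on the other ring, so this is the only direct reading of what this amidine contributes to the number, and on this read-out compound 1 and compound 4 cannot be ranked. Nothing at hand explains why the number stays within the scatter when this group is absent.

The compounds shown leave open whether any other group at this position, such as an amine, a carboxylic acid or a methoxy group, would move the number beyond the scatter. They also leave open whether the same replacement would read alike with the chloro group of compound 2 present, and what a hydrogen atom would do in place of the amidine on the other ring.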